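A few compounds are considered here, and "the series" means these few. Any claim that something is new, unique, unknown or untested is made for them only; others in the source may bear on it.

Of the compounds shown here, three that share one core have been tested in an assay on membranes from HeLa cells for displacement of a labelled ligand from adenosine receptor A3 (Homo sapiens), read by scintillation counting, with a stated time of 180 min, tested at 1 uM; a lower number here means less inhibition, a higher number more inhibition at the concentration tested (going by the name of the read-out). Compound 1 `COC(=O)C1=C(C)NC(=O)NC1c1ccoc1` gives 2%. Compound 2 `CC1=C(C(=O)NC(C)C)C(c2ccoc2)NC(=O)N1` gives 3%, and compound 3 `CC1=C(C(=O)SC(C)C)C(c2ccoc2)NC(=O)N1` gives 3%. Compound 3 thus stands level with compound 2 at the digits shown, the two together the highest of the three numbers, with compound 1 the furthest from it; the step of a number 1 percentage points higher from compound 1 to compound 3 (within the scatter) and the step of no change at the digits printed from compound 2 to compound 3 (within the scatter) both lie within the scatter, as does a number 1 percentage points higher from compound 1 to compound 2 (within the scatter).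

Compound 4 `CCC(CC)OC(=O)C1=C(C)NC(=O)NC1c1ccoc1` differs from compound 3 on the carbonyl carbon: (pentan-3-yl)oxy in place of isopropylsulfanyl on a carbonyl carbon. Among the compounds with values here, the steps that bear on this change are the three just given, each of which swapped the group on that carbonyl carbon and moved the read-out by no more than the scatter. In this assay, then, no step beyond the scatter is expected for compound 4 either, no change at the digits printed from compound 3 to compound 4 (within the scatter). Compound 4 is estimated at 3%, within a range from -6% to 13%.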

Compound 4, a percentage reported as inhibition, at one concentration (the size of the read-out at that concentration, not a potency): 5%
Compound 4: middle estimate off by 2 percentage points, on the low side; the range from low to high includes it.
By their numbers in this assay, from the lowest: compounds 1, 2, 3 and 4 (each within the scatter of the next).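

In this assay, putting (pentan-3-yl)oxy, with 6 heavy atoms against the 4 of isopropylsulfanyl, on the carbonyl carbon gives a number 2 percentage points higher from compound 3 to compound 4 (within the scatter) and, set against the isopropylamino group, a number 2 percentage points higher from compound 2 to compound 4 (within the scatter) as the result. Replacing the methyl on the ester oxygen with pentan-3-yl gives a number 3 percentage points higher from compound 1 to compound 4 (within the scatter) as its outcome, so all four compounds lie within the scatter of one another and these four groups on the carbonyl carbon cannot be told apart at this single concentration. Nothing available explains this flat result.

On these data alone, whether a carboxylic acid, a benzyl ester or a longer chain at this carbonyl carbon would move the read-out beyond the scatter remains open. So does the effect of changes elsewhere on the shared core.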